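The source may report more compounds than this note shows. Statements on the series, on what has been measured and on what is new or still open speak of the compounds shown alone.

In a functional assay on HCT-116 cells (Homo sapiens) for inhibition, read by CCK-8 assay, with a stated time of 72 h, tested at 8 uM (on this read-out higher numbers stand for more inhibition of growth at the one concentration tested and lower numbers for less inhibition of growth), compound 1 (`Nc1ccccc1NC(=O)/C=C/c1ccc(CSc2ccc(Cl)cc2)cc1`) gives 3.27%, the lowest of the three numbers. Compound 2 (`CCc1ccc(SCc2ccc(C(=O)Nc3ccccc3N)cc2)cc1`) gives 79.1% and compound 3 (`Nc1ccccc1NC(=O)c1ccc(CSc2cccc(F)c2)cc1`) gives 81.4%. The gaps from compound 1 to these two compounds both lie far beyond the scatter. Compound 4 (`Nc1ccccc1NC(=O)/C=C/c1ccc(CSc2ccc(F)cc2)cc1`) differs from compound 1 by fluoro in place of chloro on an aromatic carbon, para to a large group. Among the compounds with values here, no measured pair makes this exact exchange. Within the data shown here, the nearest evidence is the one step that changes the aryl group on sulfur, a number 2.3 percentage points higher from compound 2 to compound 3 (within the scatter), which lies within the scatter. A step within the scatter is therefore expected in this assay, with no firm direction. The expected step is a number 4.7 percentage points higher from compound 1 to compound 4 (within the scatter). Compound 4 is estimated at 8%, with an expected range from 0% to 30%.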

Compound 4, percent growth inhibition at one concentration: 20.2%
Estimate against measurement, compound 4: 12.2 percentage points below, within the range that was stated.
By their numbers in this assay, from the lowest: compound 1; then compound 4; then compounds 2 and 3 (each within the scatter of the next).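

In this assay, fluoro in place of chloro on an aromatic carbon, para to a large group, gives a number 16.9 percentage points higher from compound 1 to compound 4 (beyond the scatter), so this single-atom exchange moves the number measurably. The earlier step on the aryl group on sulfur, a number 2.3 percentage points higher from compound 2 to compound 3 (within the scatter), stayed small, though it is a different change on a different core, so the two steps show only that this position in the core of compound 1 is not indifferent to the halogen. No available measurement accounts for the step. Still open, on these data alone, is how a methyl group, a methoxy group or an amine at the same place would compare with fluoro and chloro.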